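The source may report more compounds than this note shows. Statements on the series, on what has been measured and on what is new or still open speak of the compounds shown alone.

Of the compounds shown here, two have been measured in a functional assay on A-375 cells (Homo sapiens) for antiproliferative activity, read by trypan blue exclusion, with a stated time of 48 h, tested at 5 uM; on this read-out higher numbers stand for a weaker effect at the one concentration tested and lower numbers for a stronger effect. Compound 1, `CC(=O)Nc1nc(-c2cccc(NS(=O)(=O)c3cccc(Br)c3)c2)cs1`, gives 67.4% in this assay. Compound 2, `CCCCC#Cc1ccc(S(=O)(=O)Nc2cccc(-c3csc(NC(C)=O)n3)c2)cc1`, gives 9.3% in this assay. Within the data shown here, of the two numbers, compound 2 stands lowest; the only other value, that of compound 1, is higher by an amount beyond the usual scatter, so compound 2 shows the stronger effect of the pair at the concentration tested.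

The next compound, compound 3, is `CC(=O)Nc1nc(-c2cccc(NS(=O)(=O)c3ccc(C#C[Si](C)(C)C)cc3)c2)cs1`. It differs from compound 2 at one place: a group of 4 heavy atoms (3 carbon, 1 silicon; no ring) in place of a group of 4 heavy atoms (4 carbon; no ring), on a triple-bonded carbon. Among the measured compounds shown here, no pair of measured compounds shares this change, so there is no measured step to lean on, and the expectation rests on the value of compound 2 alone. Because compound 2 gives 9.3%, the step is expected to be small, a modest rise in the number that may well stay within the scatter: a number 10.7 percentage points higher from compound 2 to compound 3 (beyond the scatter) in this assay. Compound 3 is therefore estimated to give 20% in this assay, in a range from 5% to 55%.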

Compound 3, a percentage reported as activity, at one concentration (the size of the read-out at that concentration, not a potency): 4.2%
Compound 3: middle estimate off by 15.8 percentage points, on the high side; the measured number lies below the stated range.
By their numbers in this assay, from the lowest: compounds 3 and 2 (each within the scatter of the next); then compound 1.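

Putting a group of 4 heavy atoms (3 carbon, 1 silicon) in place of butyl, on a triple-bonded carbon, gives a number 5.1 percentage points lower from compound 2 to compound 3 (within the scatter) in this assay, so this exchange cannot be told apart from the usual variation between repeated measurements. Among these compounds, this is the first step measured at this position, and it shows that the low number of compound 2 does not depend on an all-carbon group there, since compound 3 , with silicon in the group, gives 4.2% and stays within the scatter of compound 2 . No measurement at hand gives a reason for this outcome.

As far as these compounds go, with a single swap of two groups with the same heavy-atom count and no ring, it remains open how much change this position accepts, for instance with a longer chain, a phenyl ring, an amine or a carboxylic acid on the triple-bonded carbon. The read-out at one concentration is also not a potency, so compound 2 and compound 3 could still separate in a full concentration series.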